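Cyclopropyl to Furanyl on the Benzylic Carbon of Compound 1

The source may report more compounds than this note shows. Statements on the series, on what has been measured and on what is new or still open speak of the compounds shown alone.

Measured so far:
compound 1 `c1ccc(C(/N=C2\CCCCN2)C2CC2)cc1`, 36%
compound 2 `COc1ccc(C(/N=C2\CCCCCN2)C2CC2)cc1`, 40%
compound 3 `c1ccc(C(/N=C2\CCCCCN2)C2CCCCC2)cc1`, 0%

In a functional assay on the whole organism (plasma, strain Sprague-Dawley) with Rattus norvegicus as the target, with a stated time of 2 h, at a dose of 100 mg/kg by the oral route (a lower number here means a weaker effect, a higher number a stronger effect of the compound at the dose given), compound 1 gives 36%, the second highest of the three numbers. Its nearest neighbour is compound 2, which gives 40%, a number within the scatter of that of compound 1, so no order between the two can be read. Compound 3 gives 0%, which stands well beyond the scatter below compound 1 and is the furthest number of the set.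

The unmeasured compound 4 `c1ccc(C(/N=C2\CCCCN2)c2ccco2)cc1` differs from compound 1 in one place: furan-2-yl in place of cyclopropyl on a saturated chain carbon bound to an aromatic carbon and a double-bonded nitrogen. Going by the values given here, no measured pair shows this exchange, so no step of the kind can be taken from the data; only the values of compound 1 and compound 3 show that a different group on the saturated chain carbon bound to an aromatic carbon and a double-bonded nitrogen can change the read-out in this assay a great deal.

Compound 4 is therefore expected to sit somewhat below compound 1, with the step of a number 11 percentage points lower from compound 1 to compound 4 (beyond the scatter) small and not clearly beyond the scatter. The estimate for compound 4 is 25%, in a range from 0% to 55%.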

Compound 4, a percentage reported as inhibition, in the whole organism at one dose (the size of the read-out at that dose, not a potency): 27%
Compound 4: middle estimate off by 2 percentage points, on the low side; low and high end bracket the measured number.
By their numbers in this assay, from the lowest: compound 3; then compounds 4, 1 and 2 (each within the scatter of the next, the first and the last beyond it).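

In this assay, going by these compounds alone, furan-2-yl in place of cyclopropyl on the saturated chain carbon bound to an aromatic carbon and a double-bonded nitrogen gives a number 9 percentage points lower from compound 1 to compound 4 (within the scatter) as the first step at this place that rests on one exchange alone. The earlier compounds shown here showed no such step, and this one shows that, on the core of compound 1, a five-membered aromatic ring with 1 hetero atom can take the place of a three-membered non-aromatic ring of carbon only without a change in the read-out that stands beyond the scatter. No measurement shown here bears on what lies behind this result.

From the compounds shown here alone, whether an amine, a carboxylic acid or a longer chain at this place would keep the read-out within the scatter of compound 1 stays open. Also open is whether furan-2-yl would give a similar step on the core of compound 2, and since each compound is shown at one dose only, any difference in effect between compound 1 and compound 4 at other doses stays unknown.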